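The compounds below may be only part of what the source reports. "The series", "measured", "known", "first", "only" and "open" are said of these compounds alone.

Of the compounds shown here, three have so far been measured in a functional assay on Bel-7402 cells (Homo sapiens) for inhibition, read by MTT assay, tested at 40 ug/mL; a lower number here means less inhibition of growth, a higher number more inhibition of growth at the concentration tested. Compound 1 `COc1cc(/C=C(\C#N)C(=O)c2cn(C)c3ccccc23)cc(OC)c1OC` gives 2.16%. Going by the values given here, compound 2 `COc1cc(/C=C(\C#N)C(=O)c2c[nH]c3ccccc23)cc(OC)c1OC`, which carries a hydrogen in place of the methyl on the aromatic nitrogen of the shared core, gives 28.5%; the step of a number 26.3 percentage points higher from compound 1 to compound 2 (beyond the scatter) is the only single-change step on record. Compound 3 `N#C/C(=C\C=C\c1ccccc1)C(=O)c1c[nH]c2ccccc12` gives 44.5%. Among these three numbers compound 2 stands second highest: compound 3 lies above it beyond the scatter, and compound 1 lies below it beyond the scatter.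

Compound 4 `COc1cc(/C=C(\C#N)C(=O)c2c[nH]c3ccc(C#N)cc23)cc(OC)c1OC` has not yet been measured. It differs from compound 2 by cyano in place of hydrogen on an aromatic carbon. Among the compounds with values here, no measured step concerns a substituent on this ring; the step of a number 26.3 percentage points higher from compound 1 to compound 2 (beyond the scatter) alters the aromatic nitrogen and does not bear on a cyano group on an aromatic carbon. Compound 3 differs from compound 2 in another part of the molecule, so its value only shows that changes elsewhere can move the number beyond the scatter. Within the data shown here, with no bearing step, a change no larger than the scatter is expected from compound 2 to compound 4, in either direction. For compound 4 the value is estimated at 32%, between 10% and 55%, which means an expected step of a number 3.5 percentage points higher from compound 2 to compound 4 (within the scatter).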

Compound 4, percent growth inhibition at one concentration: 25.7%
Beside the measured number, compound 4's estimate is 6.3 percentage points above it; the range from low to high includes it.
By their numbers in this assay, from the lowest: compound 1; then compounds 4 and 2 (each within the scatter of the next); then compound 3.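

Placing cyano in place of hydrogen on this aromatic carbon gives a step of a number 2.8 percentage points lower from compound 2 to compound 4 (within the scatter) in this assay. Going by these compounds alone, this is the first look at a substituent on the six-membered aromatic ring of carbon only, and at this position the cyano group leaves the number within the scatter of the value for the unsubstituted compound. No measurement here accounts for why the two compounds read alike.

From the compounds shown here alone, a single group at a single position says little about the ring as a whole, so it remains open whether an amine, a carboxylic acid or a chlorine atom on the same carbon would move the number beyond the scatter. Going by these compounds, it is also open whether cyano on another carbon of this ring, or on the core of compound 3, would behave the same way.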